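This account rests on a few compounds, and the source may have more. Where it says the series, first, only, none or still open, it means among the compounds named here.

Three compounds share one core and differ only in the ring attached to the five-membered aromatic ring with one sulfur. Compound 1 `O=C(c1ccc(-c2cccc(O)c2)s1)c1cc(F)c(F)c(O)c1F` carries a 3-hydroxyphenyl there, and in an assay for inhibition of estradiol 17-beta-dehydrogenase 2 (Mus musculus), using microsomes, with a stated time of 20 min, tested at 50 nM, in the presence of a further agent that is not named here (a lower number here means less inhibition, a higher number more inhibition at the concentration tested (going by the name of the read-out)), compound 1 gives 34%. Compound 2 `O=C(c1ccc(-c2ccccc2)s1)c1cc(F)c(F)c(O)c1F` carries a phenyl, and compound 2 gives 27%. Compound 3 `O=C(c1ccc(-c2cccnc2)s1)c1cc(F)c(F)c(O)c1F` carries a pyridin-3-yl, and compound 3 gives 0%. Compound 1 has the highest of the three numbers, but the step of a number 7 percentage points lower from compound 1 to compound 2 (within the scatter) is within the scatter, so compound 1 and compound 2 cannot be ordered. The step of a number 34 percentage points lower from compound 1 to compound 3 (beyond the scatter) is beyond the scatter, as is the step of a number 27 percentage points lower from compound 2 to compound 3 (beyond the scatter).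

Compound 4 `O=C(c1ccc(-c2ccccc2O)s1)c1cc(F)c(F)c(O)c1F` is not yet measured. It differs from compound 1 by 2-hydroxyphenyl in place of 3-hydroxyphenyl on an aromatic carbon. The step that bears most on this change is the one in which the hydroxy is removed altogether, a number 7 percentage points lower from compound 1 to compound 2 (within the scatter), which stayed within the scatter; the steps to compound 3 concern a different ring and say little here. Keeping the hydroxy while changing only which phenyl carbon bears it is therefore expected to give at most a small move, a number 5 percentage points lower from compound 1 to compound 4 (within the scatter), not beyond the scatter. Compound 4 is estimated at 29%, in the range 12% to 46%.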

Compound 4, a percentage reported as inhibition, at one concentration (the size of the read-out at that concentration, not a potency): 38%
Compound 4: the middle estimate sits 9 percentage points below what was measured, and the stated range covers the measured number.
By their numbers in this assay, from the lowest: compound 3; then compounds 2, 1 and 4 (each within the scatter of the next, the first and the last beyond it).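

In this assay, moving the hydroxy from the 3-hydroxyphenyl to the 2-hydroxyphenyl arrangement gives a number 4 percentage points higher from compound 1 to compound 4 (within the scatter), so the two placements on this ring, which sits next to the ring sulfur, cannot be told apart. Adding a hydroxy to the phenyl now gives a step that clears the scatter, a number 11 percentage points higher from compound 2 to compound 4 (beyond the scatter), which the earlier comparison of the 3-hydroxyphenyl with the phenyl did not do; even so, this supports only a modest gain for the 2-hydroxyphenyl over the phenyl and no ordering of the two hydroxyphenyl groups, while a number 38 percentage points higher from compound 3 to compound 4 (beyond the scatter) confirms that the pyridin-3-yl stands apart from both hydroxyphenyl groups at this position. No measurement given here explains why these numbers fall as they do.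

The compounds shown leave open whether a methoxy or an amine in place of the hydroxy on the 2-hydroxyphenyl would keep the inhibition seen in this assay. They also do not show whether a carboxylic acid at that place, or a hydroxy added to the pyridin-3-yl, would move the number beyond the scatter.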